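This account rests on a few compounds, and the source may have more. Where it says the series, first, only, none or still open, it means among the compounds named here.

Compound 2 `C=CCc1c(O)cc(O)c2c1OC(c1cccc(O)c1)CC2=O` and compound 3 `C=CCc1cc(O)cc2c1OC(c1cccc(O)c1)CC2=O` both carry a 3-hydroxyphenyl group on their cores; how the two cores differ from each other is not broken down here. In a functional assay on aorta (Rattus norvegicus, strain Sprague-Dawley) for inhibition, with a stated time of 20 min (on this read-out higher numbers stand for larger maximal responses and lower numbers for smaller maximal responses), compound 2 gives 97.8%, and compound 3 gives 90.2%, two numbers that lie within the usual scatter of each other. Compound 1 `C=CCc1c(O)cc(O)c2c1OC(c1ccc(Cl)cc1)CC2=O` is derived from compound 2 by a single change, namely (4-chlorophenyl in place of 3-hydroxyphenyl on a saturated ring carbon). In this assay compound 1 gives 77.6%, which is a number 20.2 percentage points lower from compound 2 to compound 1 (beyond the scatter).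

Compound 4 `C=CCc1cc(O)cc2c1OC(c1ccc(Cl)cc1)CC2=O` has not yet been measured. It stands to compound 3 exactly as compound 1 stands to compound 2: the change is 4-chlorophenyl in place of 3-hydroxyphenyl on a saturated ring carbon. The place of the change reads the same word for word in both pairs, so this is the same change made a second time, now on the core of compound 3 rather than that of compound 2. Among the compounds shown it occurs twice in all, and only one of the two occurrences has been measured.

The step expected here is a number 19.2 percentage points lower from compound 3 to compound 4 (beyond the scatter), an estimate that rests on the single measured occurrence because the same change gave a number 20.2 percentage points lower from compound 2 to compound 1 (beyond the scatter). Compound 4 is accordingly expected to reach about 71% in this assay. The estimate for compound 4 is taken to span from 57% to 85%, a range widened somewhat since the step is known from one pair only.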

Compound 4, largest response reached (Emax), in percent of the reference or control that the assay uses: 95.1%
Estimate against measurement, compound 4: 24.1 percentage points below; measured number outside the range, above it.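

In this assay, 4-chlorophenyl in place of 3-hydroxyphenyl on a saturated ring carbon gave a number 4.9 percentage points higher from compound 3 to compound 4 (within the scatter), so the change did not behave on the core of compound 3 as it had on the core of compound 2: the same change on two cores in this assay, a number 20.2 percentage points lower (beyond the scatter) from compound 2 to compound 1 and a number 4.9 percentage points higher (within the scatter) from compound 3 to compound 4, 25.1 percentage points apart, beyond the scatter of two such steps

Within these two pairs, then, the result of the change on one core could not be carried over to the other, and the step seen on the core of compound 2 is no guide to the same change on the core of compound 3. This does not show which of the differences between the two cores sets the steps apart, nor how the change would turn out on any further core, as the comparison rests on just two pairs in a single assay.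

The compounds shown leave open whether either step would recur on a third core, and whether the core of compound 2 or that of compound 3 is the more typical of the series. They also leave open what a phenyl ring carrying an amine or a carboxylic acid would give on that same saturated ring carbon, on either core.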